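The source may hold more compounds than are shown below. What is called first, only, known or untested is meant among the compounds shown, and "the series" means these compounds.

Within the data shown here, compound 3 `O=C(NC(=S)Nc1ccccc1)c1ccccc1` gives 1290 nM in an assay for inhibition of epoxide hydrolase 1 (Homo sapiens), read by fluorescence, using microsomes (on this read-out lower numbers stand for stronger inhibition and higher numbers for weaker inhibition), the lowest of the three numbers measured so far. Compound 1 `O=C(NC(=S)Nc1ccc(Br)cc1)c1ccccc1` gives 3440 nM and compound 2 `CC(=O)NC(=S)Nc1ccccc1` gives 2350 nM; the step of a 2.7-fold lower number from compound 1 to compound 3 (0.43 log units; beyond the scatter) is modest, while a 1.8-fold lower number from compound 2 to compound 3 (0.26 log units; within the scatter) lies within the scatter. Compound 4 `O=C(NC(=S)Nc1ccncc1)c1ccccc1` differs from compound 3 by pyridin-4-yl in place of phenyl on an amide-type nitrogen. Among the measured compounds shown here, only a 2.7-fold lower number from compound 1 to compound 3 (0.43 log units; beyond the scatter) bears on this change, since it also altered the phenyl that leaves here, and it was modest; no measured pair shows a ring nitrogen entering at this place. A small shift, if any, is therefore expected, a 1.6-fold higher number from compound 3 to compound 4 (0.19 log units; within the scatter). Compound 4 is expected to give about 2000 nM in this assay, somewhere between 700 nM and 6000 nM.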

Compound 4, half-maximal inhibitory concentration: 2280 nM
For compound 4 the middle estimate is 1.1-fold (0.06 log units) below the measured one, within the range that was stated.
By their numbers in this assay, from the lowest: compounds 3, 4, 2 and 1 (each within the scatter of the next, the first and the last beyond it).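

The step of a 1.8-fold higher number from compound 3 to compound 4 (0.25 log units; within the scatter) shows that this place tolerates a ring nitrogen, and the hydrogen-bond acceptor counted with it, with no shift beyond the scatter. The earlier compounds shown here changed only a bromo on this ring, whereas here an atom of the ring itself is exchanged. No measured evidence bears on this result.

Going by these compounds, whether the place on the amide-type nitrogen needs an aromatic ring at all stays open, since a cyclohexyl or a longer chain could stand there instead. An amine or a carboxylic acid on the pyridin-4-yl ring is equally untested by these compounds.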